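The source may hold more compounds than are shown below. What is called first, only, known or untested is meant among the compounds shown, and "the series" means these compounds.

Four compounds share one core and differ only in two small places. Compound 1 `CCn1cc(-c2cccc(F)c2)c(=O)c2cc(F)c(N3CCNCC3)cc21` was tested in a functional assay on HeLa cells (Homo sapiens) for antiproliferative activity, read by MTT assay, with a stated time of 48 h (on this read-out lower numbers stand for stronger inhibition and higher numbers for weaker inhibition), and gives 22000 nM. Compound 2 `CCn1cc(-c2cccc(Cl)c2)c(=O)c2cc(F)c(N3CCNCC3)cc21` differs from compound 1 in one spot: chloro in place of fluoro on an aromatic carbon. In this assay compound 2 gives 16100 nM, so that change made a 1.4-fold lower number from compound 1 to compound 2 (0.14 log units; within the scatter).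

Compound 3 `O=c1c(-c2cccc(F)c2)cn(C2CC2)c2cc(N3CCNCC3)c(F)cc12` differs from compound 1 in a different spot, on the core: cyclopropyl in place of ethyl on an aromatic nitrogen. In this assay compound 3 gives 9160 nM, which is a 2.4-fold lower number from compound 1 to compound 3 (0.38 log units; beyond the scatter). The values of compound 2 and compound 3 lie within the scatter of each other, so no order between them can be read.

Compound 4 `O=c1c(-c2cccc(Cl)c2)cn(C2CC2)c2cc(N3CCNCC3)c(F)cc12` has not yet been measured. It carries the core of compound 3 and differs from compound 3 in the same way compound 2 differs from compound 1: chloro in place of fluoro on an aromatic carbon. The surroundings of the change are described identically in both pairs, so it is the same change on a core that differs only in the way described between compound 1 and compound 3. Because the earlier instance gave a 1.4-fold lower number from compound 1 to compound 2 (0.14 log units; within the scatter), a step of similar, small size is expected here, with compound 3 as the starting point. The expected step is a 1.4-fold lower number from compound 3 to compound 4 (0.15 log units; within the scatter). Compound 4 is therefore estimated to give about 6500 nM in this assay, most likely between 3000 nM and 14000 nM.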

Compound 4, half-maximal inhibitory concentration: 890 nM
Beside the measured number, compound 4's estimate is 7.3-fold (0.86 log units) above it; the whole stated range lies above it.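

In this assay, chloro in place of fluoro gives a 10-fold lower number from compound 3 to compound 4 (1.01 log units; beyond the scatter), and cyclopropyl in place of ethyl gives an 18-fold lower number from compound 2 to compound 4 (1.26 log units; beyond the scatter), so both changes have a large effect when they arrive at compound 4. The size of the step from 3-fluorophenyl to 3-chlorophenyl therefore did not carry over from the ethyl core to the cyclopropyl core, which means that the two changes do not simply add up here: the same change on two cores in this assay, a 1.4-fold lower number (0.14 log units; within the scatter) from compound 1 to compound 2 and a 10-fold lower number (1.01 log units; beyond the scatter) from compound 3 to compound 4, 7.5-fold (0.88 log units) apart, beyond the scatter of two such steps. The same gap appears when the nitrogen change is followed instead, but this rests on only four compounds and does not show why the two changes combine in this way, or whether any other pair of groups would do the same: the same change on two cores in this assay, a 2.4-fold lower number (0.38 log units; beyond the scatter) from compound 1 to compound 3 and an 18-fold lower number (1.26 log units; beyond the scatter) from compound 2 to compound 4, 7.5-fold (0.88 log units) apart, beyond the scatter of two such steps.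

The compounds shown leave open whether a bromo or a methyl group in place of the chloro would also give such a large step on the cyclopropyl core. They also leave open whether a longer chain, such as propyl, on the aromatic nitrogen would behave like ethyl or like cyclopropyl when paired with the 3-chlorophenyl group.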